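A few compounds are considered here, and "the series" means these few. Any claim that something is new, unique, unknown or untested is made for them only; others in the source may bear on it.

Working notes on the series in a physicochemical assay for acid dissociation, read by capillary electrophoresis. Compound 2 (`CC1=C[C@@](C)(c2cc(NC(=O)c3ccc(C#N)cn3)ccc2F)N=C(N)O1`) gives 7.9, the highest of the three numbers in hand. Compound 3 (`C[C@@]1(c2cc(NC(=O)c3ccc(C#N)cn3)ccc2F)C=C(CF)OC(N)=N1`) gives 6.9, and compound 1 (`N#Cc1ccc(C(=O)Nc2ccc(F)c([C@]3(C4CC4)C=C(CF)OC(N)=N3)c2)nc1`) gives 6.8.

Compound 4 (`CC1=COC(N)=N[C@]1(C)c1cc(NC(=O)c2ccc(C#N)cn2)ccc1F`) has not yet been measured. Compared with compound 2, it has the same atoms joined differently: a group of 9 heavy atoms (6 carbon, 2 nitrogen, 1 oxygen; one six-membered non-aromatic ring with 2 hetero atoms) in place of a group of 9 heavy atoms (6 carbon, 2 nitrogen, 1 oxygen; one six-membered non-aromatic ring with 2 hetero atoms), on an aromatic carbon. The group that changes sits on an aromatic carbon, and both versions contain one six-membered non-aromatic ring with 2 hetero atoms.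

Two measured steps give some context, but neither is this change. Fluoro in place of hydrogen on a saturated chain carbon bound to a double-bonded ring carbon gave a number 1.00 log units lower from compound 2 to compound 3 (beyond the scatter), and compound 4 has no such fluoro. Methyl in place of cyclopropyl on a saturated ring carbon gave a number 0.10 log units higher from compound 1 to compound 3 (within the scatter). Within the data shown here, the data hold no measured example of a rejoining like this one, so the size of the step remains uncertain.

The estimate therefore starts from compound 2 at 7.9, and no step beyond the scatter is expected. The expected change is a number 0.10 log units lower from compound 2 to compound 4 (within the scatter). For compound 4 the estimated value is 7.8, with an expected range from 7.3 to 8.3.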

Compound 4, acid dissociation constant: 8
Compound 4: middle estimate off by 0.20 log units, on the low side, within the range that was stated.
By their numbers in this assay, from the lowest: compounds 1 and 3 (each within the scatter of the next); then compounds 2 and 4 (each within the scatter of the next).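

In this assay, among these compounds, the rejoining of the group of 9 heavy atoms, on an aromatic carbon ortho to a fluoro group, gave a number 0.10 log units higher from compound 2 to compound 4 (within the scatter) and is the first measured example of this kind of change. Among the compounds shown here, at this position, then, the same atoms joined differently leave the read-out within the scatter, while fluoro in place of hydrogen remains the one measured change from compound 2 that goes beyond it, with a number 1.00 log units lower from compound 2 to compound 3 (beyond the scatter) as the step. No measurement in hand explains why the rejoining and the fluoro change differ in this way.

For the compounds shown here, the single rejoined compound leaves open whether fluoro in place of hydrogen would give a step of similar size on the rejoined group, or whether the step seen with the original group is particular to that arrangement. Also open, as far as these compounds go, is how this assay would respond to a trifluoromethyl group or an ethyl group in place of the methyl groups of compound 4, since one rejoined example cannot show how far this near-equality with compound 2 extends.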